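Amine variation at the thiocarbonyl carbon: outlook for compound 4

A few compounds are considered here, and "the series" means these few. Any claim that something is new, unique, unknown or untested is made for them only; others in the source may bear on it.

Measured so far in a functional assay on K562 cells (Homo sapiens) for cytotoxicity; on this read-out lower numbers stand for stronger inhibition and higher numbers for weaker inhibition:
compound 1 `CCN(CC)C(=S)SCc1ccc2nc(C)nc(O)c2c1` — 4400 nM
compound 2 `Cc1nc(O)c2cc(CS/C(S)=N/Cc3ccccc3)ccc2n1` — 4000 nM
compound 3 `Cc1nc(O)c2cc(CS/C(S)=N/Cc3ccco3)ccc2n1` — 2100 nM

Compound 1 stands at the highest of the three numbers. Its nearest neighbour is compound 2, whose value lies within the scatter of compound 1. The furthest is compound 3, whose value lies beyond the scatter of compound 1. Going by the values given here, the only step between compounds that differ in one place is a 1.9-fold lower number from compound 2 to compound 3 (0.28 log units; within the scatter), which concerns the group on a saturated chain carbon bound to a double-bonded nitrogen and not the thiocarbonyl carbon.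

Compound 4 `Cc1nc(O)c2cc(CSC(=S)N3CCCCC3)ccc2n1` differs from compound 1 in one place: piperidin-1-yl in place of diethylamino on a thiocarbonyl carbon. Among the compounds with values here, no measured step touches the amine on the thiocarbonyl carbon, so nothing speaks for a step in either direction in this assay; the expectation is therefore no step beyond the scatter. Compound 4 is estimated at 4000 nM, with a range from 1800 nM to 9000 nM. The expected step is a 1.1-fold lower number from compound 1 to compound 4 (0.04 log units; within the scatter).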

Compound 4, half-maximal inhibitory concentration: 11300 nM
Beside the measured number, compound 4's estimate is 2.8-fold (0.45 log units) below it, and the stated range ends below it.
By their numbers in this assay, from the lowest: compounds 3, 2 and 1 (each within the scatter of the next, the first and the last beyond it); then compound 4.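

In this assay, going by these compounds alone, the amine on the thiocarbonyl carbon turns out to be a place that responds to change, which no earlier step could show: a 2.6-fold higher number from compound 1 to compound 4 (0.41 log units; beyond the scatter) and is the first step read at this position. The step is modest, yet it comes from replacing the open-chain diethylamino group with the ring of piperidin-1-yl, and neither group carries a hydrogen-bond donor, a hydrogen-bond acceptor or a net charge. Nothing measured on these compounds bears on why the number rises.

Still open, on these data alone, is whether any ring amine on the thiocarbonyl carbon gives the same shift, or only piperidin-1-yl; pyrrolidin-1-yl and morpholin-4-yl would separate the two. Also open, as far as these compounds go, is how a smaller open-chain amine such as dimethylamino compares with diethylamino here.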